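Halogen Exchange on the Aryl Ring: Compound 3

The source may hold more compounds than are shown below. What is called first, only, known or untested is meant among the compounds shown, and "the series" means these compounds.

Within the data shown here, compound 2 `CC(C)(C)C(=O)NCCCCN1CCN(c2ccc(F)cc2)CC1` gives 126 nM in an assay on HEK293 cells for binding affinity to D(4) dopamine receptor (Homo sapiens), read by radioligand binding (a higher number here means a weaker inhibitor, a lower number a stronger inhibitor), and stands as the lower of the two numbers measured so far, compound 1 `COc1ccc(N2CCN(CCCCNC(=O)C(C)(C)C)CC2)cc1` giving 316 nM in this assay. Among the measured compounds shown here, the single measured step at this position, a 2.5-fold lower number from compound 1 to compound 2 (0.40 log units; beyond the scatter), concerns fluoro in place of methoxy and so bears only loosely on compound 3 `CC(C)(C)C(=O)NCCCCN1CCN(c2ccc(Br)cc2)CC1`, which carries bromo in place of fluoro on an aromatic carbon. For the measured compounds named here, no measured pair exchanges one halogen for another. A step of a 1.3-fold lower number from compound 2 to compound 3 (0.10 log units; within the scatter) is expected, close to the scatter. Compound 3 is estimated at 100 nM, with a range from 40 nM to 250 nM.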

Compound 3, inhibition constant: 31.6 nM
For compound 3 the middle estimate is 3.2-fold (0.50 log units) above the measured one, and the stated range ends above it.
By their numbers in this assay, from the lowest: compound 3; then compound 2; then compound 1.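

In this assay, among these compounds, the choice of halogen matters at this position: bromo in place of fluoro gives a 4.0-fold lower number from compound 2 to compound 3 (0.60 log units; beyond the scatter) as the first measured exchange of one halogen for another. Bromo in place of methoxy gives a 10-fold lower number from compound 1 to compound 3 (1.00 log units; beyond the scatter) and is the largest step so far, so compound 3 stands lowest of the three, with its steps to both others beyond the scatter. Nothing at hand accounts for the gap between the two halogens.

Open, on these data alone, is whether chloro or iodo on this aromatic carbon would fall in line with fluoro and bromo, and whether a trifluoromethyl group or an amine there would match compound 3.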